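The compounds below may be only part of what the source reports. "The series", "measured", "known", "first", "only" and "open" are said of these compounds alone.

For the measured compounds named here, compound 1 `O=C(CCCCCCC(=O)N1C/C=C/COCc2cccc(c2)-c2ccnc(n2)Nc2cccc(c2)C1)NO` stands as the weaker of the two measured members: in a functional assay on HEL cells (Homo sapiens) for inhibition, read by CellTiter-Glo, with a stated time of 48 h (a lower number here means a stronger inhibitor of growth, a higher number a weaker inhibitor of growth), compound 1 gives 5030 nM, the highest of the two numbers known. Going by the values given here, its nearest neighbour is compound 2 `O=C(CCCCCCN1C/C=C/COCc2cccc(c2)-c2ccnc(n2)Nc2cccc(c2)C1)NO`, which in this assay gives 700 nM; the one measured step runs a 7.2-fold lower number from compound 1 to compound 2 (0.86 log units; beyond the scatter), and it concerns the carbonyl on the amine nitrogen in the ring, not the chain that carries the hydroxycarbamoyl group.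

Compound 3 `O=C(CCCCCCCC(=O)N1C/C=C/COCc2cccc(c2)-c2ccnc(n2)Nc2cccc(c2)C1)NO` keeps that carbonyl of compound 1 and differs only in the chain: (hydroxycarbamoyl)methyl in place of hydroxycarbamoyl on a saturated chain carbon, six bonds along the chain from a carbonyl carbon. Among the compounds with values here, no measured step changes the length of this chain, so the step from compound 1 to compound 2 offers no direct guide to it. With nothing to set against the change, the expectation is a step within or just beyond the scatter, with a slight lean toward a lower number, namely a 1.4-fold lower number from compound 1 to compound 3 (0.16 log units; within the scatter) as estimated here. Compound 3 is therefore expected to give about 3500 nM in this assay, with a range of 1200 nM to 10000 nM.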

Compound 3, concentration for 50% growth inhibition: 4780 nM
Compound 3: middle estimate off by 1.4-fold (0.14 log units), on the low side; the measured number falls inside the stated range.
By their numbers in this assay, from the lowest: compound 2; then compounds 3 and 1 (each within the scatter of the next).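

For the compounds shown here, on a saturated chain carbon, six bonds along the chain from a carbonyl carbon, (hydroxycarbamoyl)methyl in place of hydroxycarbamoyl gives a 1.1-fold lower number from compound 1 to compound 3 (0.02 log units; within the scatter) in this assay, the first reading of chain length. Going by these compounds alone, with the carbonyl on the ring amine nitrogen kept, this lengthening leaves compound 1 and compound 3 inseparable, while the only step beyond the scatter so far remains the change at that nitrogen, a 7.2-fold lower number from compound 1 to compound 2 (0.86 log units; beyond the scatter), so at this stage the number follows that carbonyl and not this single chain extension. No independent measurement bears on why the chain change leaves the number within the scatter.

Going by these compounds, it remains open whether a longer chain, such as one carrying 2-(hydroxycarbamoyl)ethyl at this carbon, or a shorter chain would stay within the scatter of compound 1, or whether the flat reading holds only over this one step. Also open, on these data alone, are whether the same extension behaves alike on the carbonyl-free chain of compound 2, and whether a carboxylic acid in place of hydroxycarbamoyl would keep any of the growth inhibition.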